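Notes on the step from compound 2 to compound 3

The source may report more compounds than this note shows. Statements on the series, on what has been measured and on what is new or still open speak of the compounds shown alone.

compound 1 `CCCCCSc1nc(OC(=O)c2cc3ccccc3o2)c2cn[nH]c2n1`: 19800 nM
compound 2 `CCCCCSc1nc(OC(=O)c2ccccc2)c2cn[nH]c2n1`: 19800 nM

Both values come from a functional assay on K562 cells (Homo sapiens) for antiproliferative activity, read by fluorescence, with a stated time of 3 days; on this read-out higher numbers stand for weaker inhibition and lower numbers for stronger inhibition. Compound 2 stands level with compound 1, its nearest neighbour in the series, at the digits reported. The next structure is compound 3 `CCCCCSc1nc(OC(=O)c2ccco2)c2cn[nH]c2n1`, which has furan-2-yl in place of phenyl on a carbonyl carbon.

Among the measured compounds shown here, one measured step bears on this change: no change at the digits printed from compound 1 to compound 2 (within the scatter). It exchanges one aromatic group for another at the same place, and its size lies within the scatter. For the measured compounds named here, this is thin evidence, since it is a single step and no measured compound carries furan-2-yl. Even so, the only precedent at this place shows no measurable shift, so neither a step beyond the scatter nor a particular direction is expected in this assay. The expected step is no change at the digits printed from compound 2 to compound 3 (within the scatter). The estimated value for compound 3 is 19800 nM, with an expected range of 9000 nM to 42000 nM.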

Compound 3, half-maximal inhibitory concentration: 19800 nM
Compound 3: middle estimate and measured number agree at the digits printed, and the stated range covers the measured number.
By their numbers in this assay, from the lowest: compounds 1, 2 and 3 (each within the scatter of the next).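

In this assay the replacement of phenyl by furan-2-yl on a carbonyl carbon gives no change at the digits printed from compound 2 to compound 3 (within the scatter) and the replacement of 1-benzofuran-2-yl by furan-2-yl gives no change at the digits printed from compound 1 to compound 3 (within the scatter) so the series now has a third aromatic group at this place, and the three compounds read alike. The earlier pair compared only 1-benzofuran-2-yl with phenyl, whereas furan-2-yl adds a single five-membered aromatic ring with 1 hetero atom, 5 heavy atoms against the 6 of phenyl, and 1 hydrogen-bond acceptor against none, and none of these differences comes with a step beyond the scatter at this place. No measurement at hand gives a reason for this flat reading.

The compounds shown carry only unsubstituted aromatic groups at this place, so it remains open whether a non-aromatic group such as cyclohexyl, a longer chain, or a phenyl bearing an amine or a carboxylic acid would read differently in this assay. On these data alone, the shared core and the ester oxygen next to the carbonyl group are the same in all three compounds, so their part in the reading also remains open.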